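Moving the Methyl Group on the Sulfonyl Ring

The source may hold more compounds than are shown below. What is called first, only, known or untested is meant among the compounds shown, and "the series" means these compounds.

- Compound 1 `Cc1ccc(S(=O)(=O)NC(C2=CC(=O)c3c(O)ccc(O)c3C2=O)C(C)C)cc1` in a functional assay on HL-60 cells (Homo sapiens) for cytotoxicity, read by MTT assay (a lower number here means a stronger inhibitor, a higher number a weaker inhibitor), has "not determined" (no result reported)
- Compound 2 `Cc1ccccc1S(=O)(=O)NC(C1=CC(=O)c2c(O)ccc(O)c2C1=O)C(C)C` has 190 nM
- Compound 3 `Cc1ccc(S(=O)(=O)NC(C)C2=CC(=O)c3c(O)ccc(O)c3C2=O)cc1` has 30 nM

Of the two numbers available, compound 3 has the lower one, and the gap to compound 2 lies beyond the scatter. Compound 4 `Cc1ccccc1S(=O)(=O)NC(C)C1=CC(=O)c2c(O)ccc(O)c2C1=O` has the same atoms as compound 3, joined differently, with 2-methylphenyl in place of 4-methylphenyl on a sulfonyl sulfur. Among the compounds with values here, no measured pair shows this change alone, so the expectation starts from compound 3 (30 nM) and remains uncertain. In this assay the expected step is small, towards a higher number, and inside the scatter (a 1.5-fold higher number from compound 3 to compound 4 (0.18 log units; within the scatter)). Compound 4 is expected at about 45 nM (estimated range 15 nM to 130 nM).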

Compound 4, half-maximal inhibitory concentration: 70 nM
Compound 4: middle estimate off by 1.6-fold (0.19 log units), on the low side; the measured number falls inside the stated range.
By their numbers in this assay, from the lowest: compound 3; then compound 4; then compound 2.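

The methyl group's place on the sulfonyl ring matters when nothing else changes: with 2-methylphenyl in place of 4-methylphenyl, this assay shows (a 2.3-fold higher number from compound 3 to compound 4 (0.37 log units; beyond the scatter)). The group on the chain carbon matters as well, since methyl in place of isopropyl gives (a 2.7-fold lower number from compound 2 to compound 4 (0.43 log units; beyond the scatter)). No evidence here explains either step.

Going by these compounds, with compound 1 at ("not determined" (no result reported)), the effect of isopropyl alongside 4-methylphenyl stays open. Also open, on these data alone, is how a chlorine or a methoxy group on the sulfonyl ring would compare with methyl.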